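Returning to a carbon-only ring on the amide carbonyl

A few compounds are considered here, and "the series" means these few. Any claim that something is new, unique, unknown or untested is made for them only; others in the source may bear on it.

In a functional assay on HEK293 cells for agonist activity at 5-hydroxytryptamine receptor 1F (Homo sapiens), read by FLIPR, with a stated time of 60 min (on this read-out lower numbers stand for stronger inhibition and higher numbers for weaker inhibition), compound 3 `CN1CCC(=C(F)c2cccc(NC(=O)c3ccc(Cl)cn3)n2)CC1` gives 161 nM, the highest of the three numbers measured; compound 1 `CN1CCC(=C(F)c2cccc(NC(=O)c3ccc(Cl)cc3)n2)CC1` gives 29.4 nM and compound 2 `CN1CCC(=C(F)c2cccc(NC(=O)c3ccc(Cl)cc3F)n2)CC1` gives 23.4 nM. Compound 4 `CN1CCC(=C(F)c2cccc(NC(=O)c3ccc(F)cc3)n2)CC1` differs from compound 3 by 4-fluorophenyl in place of 5-chloropyridin-2-yl on a carbonyl carbon. The step from compound 1 to compound 3 bears on this change most directly: a 5.5-fold higher number from compound 1 to compound 3 (0.74 log units; beyond the scatter), and the same change also shows as a 6.9-fold higher number from compound 2 to compound 3 (0.84 log units; beyond the scatter). Returning to a ring of carbon only is therefore expected to undo most of that rise in this assay, though no measured step compares chloro with fluoro on the phenyl ring, so some uncertainty remains. Compound 4 is expected to give 40 nM, between 15 nM and 120 nM, a step of a 4.0-fold lower number from compound 3 to compound 4 (0.60 log units; beyond the scatter).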

Compound 4, half-maximal inhibitory concentration: 6.36 nM
Beside the measured number, compound 4's estimate is 6.3-fold (0.80 log units) above it; the whole stated range lies above it.
By their numbers in this assay, from the lowest: compound 4; then compounds 2 and 1 (each within the scatter of the next); then compound 3.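

In this assay the group on the carbonyl carbon proves decisive, as 4-fluorophenyl in place of 5-chloropyridin-2-yl gives a large step (a 25-fold lower number from compound 3 to compound 4 (1.40 log units; beyond the scatter)). Fluoro in place of chloro on an aromatic carbon, a change the earlier compounds did not test, also matters (a 4.6-fold lower number from compound 1 to compound 4 (0.66 log units; beyond the scatter)), and 4-fluorophenyl in place of 4-chloro-2-fluorophenyl gives a similar gain (a 3.7-fold lower number from compound 2 to compound 4 (0.57 log units; beyond the scatter)). Compound 4 thus has the lowest number of the four, beyond the scatter of each other compound. No evidence available here explains these steps. Going by these compounds, whether a nitrile or a methoxy group in place of that fluoro would keep this gain remains open.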